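The source may hold more compounds than are shown below. What is called first, only, known or untested is meant among the compounds shown, and "the series" means these compounds.

Working notes on the series, read in a functional assay on OVCAR-8 cells (Homo sapiens); a lower number here means a stronger inhibitor of growth, a higher number a weaker inhibitor of growth. Compound 1 (`N#Cc1ccc(/C=C/S(=O)(=O)Cc2ccc(Nc3ncnc4ccccc34)cc2)cc1`) reads > 100000 nM, which is a limit of the assay and not a number. Compound 2 (`O=S(=O)(/C=C/c1ccc(Cl)c(Cl)c1)Cc1ccc(Nc2ncnc3ccccc23)cc1`) gives 14000 nM. Among the measured compounds shown here, compound 3 (`O=S(=O)(/C=C/c1ccc(Cl)c(Cl)c1)Cc1ccc(Nc2ncnc3ccc(Br)cc23)cc1`) gives 100 nM, the lower of the two true numbers so far. Compound 4 (`O=S(=O)(/C=C/c1ccc(F)cc1F)Cc1ccc(Nc2ncnc3ccc(Br)cc23)cc1`) is still to be measured and differs only in the group on the double-bonded chain carbon: 2,4-difluorophenyl in place of 3,4-dichlorophenyl on a double-bonded chain carbon bound to a double-bonded chain carbon.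

For the measured compounds named here, two measured steps bear on this. The closer one, an at least 7.1-fold lower number from compound 1 to compound 2 (0.85 log units; beyond the scatter), is an exchange at the same place, and its size is only a bound. The other, a 140-fold lower number from compound 2 to compound 3 (2.15 log units; beyond the scatter), is the large step from adding bromo, which compound 4 retains. Because of an at least 7.1-fold lower number from compound 1 to compound 2 (0.85 log units; beyond the scatter) the group at this place is expected to matter. No difluorophenyl group has been measured, so a modest step towards a higher number in this assay is expected, with wide uncertainty. The expected change is a 3.0-fold higher number from compound 3 to compound 4 (0.48 log units; beyond the scatter). For compound 4 the estimate is 300 nM, with an expected range of 60 nM to 2000 nM.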

Compound 4, concentration for 50% growth inhibition: 100000 nM
For compound 4 the middle estimate is 330-fold (2.52 log units) below the measured one; the whole stated range lies below it.
By their numbers in this assay, from the lowest: compound 3; then compound 2; then compound 4.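

In this assay, the exchange of 3,4-dichlorophenyl for 2,4-difluorophenyl gives a 1000-fold higher number from compound 3 to compound 4 (3.00 log units; beyond the scatter), a step larger in size than the gain from adding bromo, a 140-fold lower number from compound 2 to compound 3 (2.15 log units; beyond the scatter). The bromo group alone does not secure a low number, and the earlier exchange at this place, an at least 7.1-fold lower number from compound 1 to compound 2 (0.85 log units; beyond the scatter), gave only a bound, whereas this step has a measured size. The reading for compound 4 coincides with the number of a limit of this assay: the limit of > 100000 nM in this assay, at which 1 of the 4 values shown sits.

The halogen and its place on the ring differ together between compound 3 and compound 4, and the compounds shown do not separate the two. Going by these compounds, how a phenyl ring carrying a methoxy group or an amine would read at this place also remains open.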